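A few compounds are considered here, and "the series" means these few. Any claim that something is new, unique, unknown or untested is made for them only; others in the source may bear on it.

Working notes on the series. Compound 3 `O=C(CCCCC1CCSS1)OC1CCN(Cc2ccccc2)CC1` gives 5560 nM in an assay on membranes from brain for displacement of a labelled ligand from Sigma non-opioid intracellular receptor 1 (Cavia porcellus), read by scintillation counting, with a stated time of 150 min (on this read-out lower numbers stand for stronger inhibition and higher numbers for weaker inhibition), the highest number among the three measured compounds; compound 2 `O=C(CCCCC1CCSS1)OC1CCN(CC2CCCCC2)CC1` gives 1140 nM and compound 1 `O=C(CCCCC1CCSS1)N1CCN(C2CCCCC2)CC1` gives 400 nM. Within the data shown here, the only measured step near this position is a 4.9-fold higher number from compound 2 to compound 3 (0.69 log units; beyond the scatter). Compound 4 `O=C(CCCCC1CCSS1)OC1CCN(CCCc2ccccc2)CC1` is not yet measured; it differs from compound 3 by phenethyl in place of phenyl on a saturated chain carbon bound to an amine nitrogen in a ring. Among the measured compounds shown here, no measured pair shows a chain lengthening of this kind, so the step from compound 2 to compound 3 bears on it only indirectly. The expectation for compound 4 in this assay is a lower number than for compound 3, estimated as a 3.7-fold lower number from compound 3 to compound 4 (0.57 log units; beyond the scatter). Compound 4 is therefore expected near 1500 nM, with a range from 400 nM to 5500 nM.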

Compound 4, inhibition constant: 25700 nM
Compound 4: middle estimate off by 17-fold (1.23 log units), on the low side; the measured number lies above the stated range.
By their numbers in this assay, from the lowest: compound 1; then compound 2; then compound 3; then compound 4.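

In this assay, among these compounds, lengthening the chain on the ring amine nitrogen does not help: phenethyl in place of phenyl gives a 4.6-fold higher number from compound 3 to compound 4 (0.66 log units; beyond the scatter), the first measured reading of chain length at this place. Against cyclohexyl the gap widens to a 23-fold higher number from compound 2 to compound 4 (1.35 log units; beyond the scatter), so among these esters the number rises from cyclohexyl through phenyl to phenethyl. No evidence at hand accounts for this rise.

Open, as far as these compounds go, is whether a cyclohexyl ring on the longer chain would follow the same direction. Also open, from the compounds shown here alone, is how a methoxy group on the phenyl ring of compound 4 would read here.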